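Swapping chloro for fluoro on a weakly active compound

This account rests on a few compounds, and the source may have more. Where it says the series, first, only, none or still open, it means among the compounds named here.

Measured in a functional assay on LNCaP cells (Homo sapiens) for cytotoxicity, read by MTT assay (on this read-out lower numbers stand for stronger inhibition and higher numbers for weaker inhibition), so far:
- compound 1 `COc1ccc(CSc2nnc([C@@H](C)c3ccc4cc(OC)ccc4c3)n2-c2ccc(Cl)cc2)cc1` (<= 400000 nM as a limit, not a number)
- compound 2 `COc1cccc(CSc2nnc([C@@H](C)c3ccc4cc(OC)ccc4c3)n2-c2ccc(Cl)cc2)c1` (162000 nM)
- compound 3 `COc1ccc2cc([C@H](C)c3nnc(SCc4ccc(Cl)cc4)n3-c3ccc(Cl)cc3)ccc2c1` (110000 nM)

Compound 1 comes with only the limit of <= 400000 nM in this assay, at which 1 of the 3 values shown sits, and no number. The next compound, compound 4 `COc1ccc(CSc2nnc([C@@H](C)c3ccc4cc(OC)ccc4c3)n2-c2ccc(F)cc2)cc1`, differs from compound 1 by fluoro in place of chloro on an aromatic carbon and is fluoro in place of chloro on an aromatic carbon, a move from 4-chlorophenyl to 4-fluorophenyl.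

Within the data shown here, no measured step touches that 4-chlorophenyl. Both a step that the limit leaves unreadable from compound 1 to compound 2 and a step that the limit leaves unreadable from compound 1 to compound 3 leave it unchanged and cannot be read. Among the measured compounds shown here, the only readable step, a 1.5-fold lower number from compound 2 to compound 3 (0.17 log units; within the scatter), also leaves it in place. The data therefore give no size or direction for this change, and no step beyond the scatter is expected in this assay here. For the measured compounds named here, the only numbers are those of compound 2 (162000 nM) and compound 3 (110000 nM), so the estimate is placed near them. The estimate also stays close to the limit that compound 1 carries. The expected result is a step that the limit leaves unreadable from compound 1 to compound 4 and it is set against a limit. In this assay compound 4 is estimated at 200000 nM within an expected range from 80000 nM to 400000 nM for now.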

Compound 4, half-maximal inhibitory concentration: 22800 nM
Beside the measured number, compound 4's estimate is 8.8-fold (0.94 log units) above it, and the stated range ends above it.
By their numbers in this assay, from the lowest: compound 4; then compounds 3 and 2 (each within the scatter of the next).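

Among these compounds, no step from compound 1 to compound 4 can be read, because compound 1 carries a limit and no number: the limit of <= 400000 nM in this assay, at which 1 of the 4 values shown sits. The compounds shown leave open the size and direction of any change in value when fluoro replaces chloro on this aromatic carbon.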